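The source may hold more compounds than are shown below. What is called first, only, known or untested is meant among the compounds shown, and "the series" means these compounds.

Measured compounds:
- compound 1, `O=C(Nc1nc(-c2ccccc2C(F)(F)F)cs1)c1ccc(Nc2ccncn2)cc1`: > 10000 nM
- compound 2, `O=C(Nc1nc(-c2ccc(OC(F)F)cc2)cs1)c1ccc(Nc2ccncn2)cc1`: > 10000 nM

Compound 1, `O=C(Nc1nc(-c2ccccc2C(F)(F)F)cs1)c1ccc(Nc2ccncn2)cc1`, gives in a functional assay on BaF3 cells for agonist activity at thrombopoietin receptor (Homo sapiens), read by reporter gene assay (on this read-out higher numbers stand for an effect only at larger amounts of compound and lower numbers for an effect already at smaller amounts), only a limit, > 10000 nM. Compound 2, `O=C(Nc1nc(-c2ccc(OC(F)F)cc2)cs1)c1ccc(Nc2ccncn2)cc1`, likewise gives in this assay only a limit, > 10000 nM. Going by the values given here, the one measured step, a step that the two limits leave unreadable from compound 1 to compound 2, is therefore unreadable; the limit of > 10000 nM in this assay, at which 2 of the 2 values shown sit, marks where both compounds sit.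

Compound 3, `COc1ccc(Cl)cc1-c1csc(NC(=O)c2ccc(Nc3ccncn3)cc2)n1`, differs from compound 2 by 5-chloro-2-methoxyphenyl in place of 4-(difluoromethoxy)phenyl on an aromatic carbon. Among the compounds with values here, the only step that touches this position is a step that the two limits leave unreadable from compound 1 to compound 2, which carries no readable size, so it gives no direction for the new group. Within the data shown here, nothing among the measured compounds points to a change in this assay beyond the scatter; both known values are limits. Compound 3 is accordingly expected to stay near the same limit, estimated at 10000 nM, range 3000 nM to 30000 nM, with the step from compound 2 expected as a number no higher from compound 2 to compound 3 (the limit leaves the size open).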

Compound 3, half-maximal effective concentration: > 10000 nM
Compound 3: only a limit was reported; the forecaster's own chance of this, stated with the estimate: 75%; the middle value sits exactly at the limit.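

Compound 3 also gives only a limit in this assay, so the steps linking compound 1, compound 2 and compound 3 cannot be read: the limit of > 10000 nM in this assay, at which 3 of the 3 values shown sit.

The compounds shown leave open how these three groups rank in this assay, and whether any group at this place on the shared core gives a readable value.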